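The compounds below may be only part of what the source reports. "The series", "measured", "known", "first", "only" and "open" are said of these compounds alone.

Notes on the styryl series in a functional assay on SKHep cells (Homo sapiens) for antiproliferative activity, read by MTT assay, with a stated time of 12 h; on this read-out higher numbers stand for weaker inhibition and lower numbers for stronger inhibition. Compound 1 `COc1cc(/C=C/c2cc(=O)c3c(OC)cc(OC)cc3o2)cc(OC)c1` gives 23700 nM, and compound 2 `COc1cc(OC)c2c(=O)cc(/C=C/c3ccc(C(F)(F)F)cc3)oc2c1` gives 20600 nM; these two values sit within the usual scatter of each other, so no order between them is claimed. Compound 3 `COc1cc(OC)c2c(=O)cc(/C=C/c3ccc(Br)cc3)oc2c1` returns only a limit in this assay, > 40000 nM, and not a number. Among the compounds with values here, the one single-point step measured so far is an at least 1.9-fold higher number from compound 2 to compound 3 (0.28 log units; that floor lies within the scatter), bromo in place of trifluoromethyl on an aromatic carbon, and its floor lies inside the scatter; it cannot be read as a true difference, since the bromo compound sits at the limit of > 40000 nM in this assay, at which 1 of the 3 values shown sits.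

Compound 4 `COc1cc(OC)c2c(=O)cc(/C=C/c3ccccc3)oc2c1` has not yet been tested in this assay. Against compound 3 it shows (hydrogen in place of bromo on an aromatic carbon). Within the data shown here, no measured step removes a substituent from that aromatic carbon altogether, so the expectation rests on the weak activity shared across compounds 1, 2 and 3 rather than on a directly comparable change. Compound 4 is therefore expected to stay in the same weakly active region, with a step of an at least 1.1-fold lower number from compound 3 to compound 4 (0.05 log units; that floor lies within the scatter) that may well be within the scatter. The estimate for compound 4 in this assay is 35000 nM, with a plausible range from 15000 nM to 80000 nM, and a fair chance that only a limit is again reported.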

Compound 4, half-maximal inhibitory concentration: 26000 nM
The estimate for compound 4 lay 1.3-fold (0.13 log units) above the measured number; measured number inside the range.
By their numbers in this assay, from the lowest: compounds 2, 1 and 4 (each within the scatter of the next). At a limit, above all of these: compound 3.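

With hydrogen on this aromatic carbon, para to a large group, the position can now be read with no substituent at all in this assay. Hydrogen in place of trifluoromethyl gives a 1.3-fold higher number from compound 2 to compound 4 (0.10 log units; within the scatter), so the bare phenyl of compound 4 cannot be told apart from the trifluoromethyl compound, and trifluoromethyl shows no measurable gain over hydrogen here. Going from 4-bromophenyl to phenyl gives an at least 1.5-fold lower number from compound 3 to compound 4 (0.18 log units; that floor lies within the scatter), and this step cannot be read as a true difference, since its floor lies inside the scatter and compound 3 is held only by a limit, not a number: the limit of > 40000 nM in this assay, at which 1 of the 4 values shown sits.

Open, going by these compounds, is whether any group on this aromatic carbon can move the number beyond the scatter, for instance an amine, a carboxylic acid or a longer chain, since hydrogen and trifluoromethyl give no readable difference. Also open, on these data alone, is whether the bromo compound truly lies apart from the phenyl compound, and whether changes to the shared core would matter more than changes at this position.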